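The source may hold more compounds than are shown below. What is called first, only, known or untested is meant among the compounds shown, and "the series" means these compounds.

Working notes on the series. Compound 1 `Cc1cc(C(=O)O)nn1Cc1cc(Br)ccc1OCc1ccc(Cl)cc1Cl` is the reference point; in a functional assay on CHO-K1 cells for antagonist activity at prostaglandin E2 receptor EP1 subtype (Homo sapiens), read by FLIPR (on this read-out higher numbers stand for weaker inhibition and lower numbers for stronger inhibition), compound 1 gives 0.49 nM. For the measured compounds named here, compound 2 `Cc1cc(C(=O)O)nn1Cc1cc(Br)ccc1OCc1ccc(Cl)cc1` has lost one chloro group, and in this assay compound 2 gives 8.71 nM, the highest of the two numbers measured so far, the nearest neighbour being compound 1 at a lower number. Going by the values given here, the single measured step, an 18-fold higher number from compound 1 to compound 2 (1.25 log units; beyond the scatter), shows that removing a halogen from the benzyl ring costs a large amount of potency.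

Compound 3 `Cc1cc(C(=O)O)nn1Cc1cc(Br)ccc1OCc1ccc(F)cc1` carries the change (fluoro in place of chloro on an aromatic carbon), a halogen for a halogen rather than halogen for hydrogen. Among the compounds with values here, no measured step covers this exact exchange; the one step that bears on it, from compound 1 to compound 2, is an upper bound on what halogen loss does. The number for compound 3 in this assay is therefore expected to rise moderately, with a 2.3-fold higher number from compound 2 to compound 3 (0.36 log units; beyond the scatter) as the estimated step. For compound 3 the expected value is 20 nM, with a range from 8 nM to 60 nM.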

Compound 3, inhibition constant: 11.8 nM
Beside the measured number, compound 3's estimate is 1.7-fold (0.23 log units) above it; low and high end bracket the measured number.
By their numbers in this assay, from the lowest: compound 1; then compounds 2 and 3 (each within the scatter of the next).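

At the place para to a large group, fluoro and chloro read alike in this assay (a 1.4-fold higher number from compound 2 to compound 3 (0.13 log units; within the scatter)), so the identity of this halogen makes no difference that can be resolved between these two compounds. Exchanging it for fluoro does not recover the potency of the dichloro reference, as the change from the 2,4-dichlorophenyl group to the 4-fluorophenyl group shows (a 24-fold higher number from compound 1 to compound 3 (1.38 log units; beyond the scatter)). No evidence is available on why these two halogens read alike.

From the compounds shown here alone, whether a methyl, methoxy or trifluoromethyl group at this place would read like the two halogens remains open. Going by these compounds, it is also open whether a fluoro group in place of the other chloro of compound 1 would keep that compound's potency.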